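Dropping the chloro from the thiazole aryl of compound 2

The source may hold more compounds than are shown below. What is called first, only, known or untested is meant among the compounds shown, and "the series" means these compounds.

Measured compounds:
compound 1 `COc1cccc(-c2nc(SCC(=O)c3sc(-c4ccccc4)nc3C)[nH]c(=O)c2C#N)c1`, 99%
compound 2 `Cc1nc(-c2ccc(Cl)cc2)sc1C(=O)CSc1nc(-c2cccc(Cl)c2)c(C#N)c(=O)[nH]1`, 80.2%

In a functional assay on U-87MG ATCC cells for antiproliferative activity against U-87 MG (Homo sapiens), read by MTT assay, with a stated time of 48 h, tested at 5 uM (on this read-out lower numbers stand for a stronger effect and higher numbers for a weaker effect at the one concentration tested), compound 2 gives 80.2%, the lowest of the two numbers in hand. Compound 1 gives 99% in this assay, a number higher than that of compound 2 by more than the usual scatter; the two differ in two places, so their pair on its own does not tell which change matters.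

Compound 3 `Cc1nc(-c2ccccc2)sc1C(=O)CSc1nc(-c2cccc(Cl)c2)c(C#N)c(=O)[nH]1` has not yet been measured. It differs from compound 2 in one place only: hydrogen in place of chloro on an aromatic carbon, on an aromatic carbon of a six-membered aromatic ring of carbon only, para to a large group. Cut one bond further out, the difference reads 4-chlorophenyl to phenyl.

For the measured compounds named here, no measured pair shows this change alone, so the expectation rests on compound 2 being the lower of the two numbers. The expected step of a number 9.8 percentage points higher from compound 2 to compound 3 (within the scatter) is upward, modest, and may not exceed the scatter. Compound 3 is therefore expected to give about 90% in this assay, within a range from 76% to 102%.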

Compound 3, a percentage reported as activity, at one concentration (the size of the read-out at that concentration, not a potency): 86.9%
Compound 3: the middle estimate sits 3.1 percentage points above what was measured, and the stated range covers the measured number.
By their numbers in this assay, from the lowest: compounds 2 and 3 (each within the scatter of the next); then compound 1.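

In this assay the swap of 4-chlorophenyl to phenyl, hydrogen in place of chloro on an aromatic carbon para to a large group, gives a number 6.7 percentage points higher from compound 2 to compound 3 (within the scatter) and so, taken alone, does not move the read-out beyond the usual scatter. Compound 3 also isolates the other difference between the first two compounds: chloro in place of methoxy on an aromatic carbon gives a number 12.1 percentage points lower from compound 1 to compound 3 (beyond the scatter) and, unlike the loss of the para chloro, this modest step lies beyond the scatter, which makes it the one single change shown here that separates two compounds in this assay. Nothing in hand gives a reason for either step.

At the para place only chloro and hydrogen are shown, so it remains open whether a larger or differently built substituent there, such as an amine, a carboxylic acid or a longer alkyl chain, would shift the read-out beyond the scatter. On the other aryl ring only methoxy and chloro are compared, and what fluoro or trifluoromethyl would give in that place is open too.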